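This account rests on a few compounds, and the source may have more. Where it says the series, first, only, none or still open, it means among the compounds named here.

Measured compounds:
Compound 1, `C/C(=N\O)c1ccc(NC(=O)CSc2nnc(-c3ccccc3)n2-c2ccccc2)cc1`: 67%
Compound 2, `COc1ccc(-c2nnc(SCC(=O)Nc3ccc(/C(C)=N/O)cc3)n2-c2ccccc2)cc1`: 69%
Compound 3, `CCn1c(SCC(=O)Nc2ccc(C(C)=O)cc2)nnc1-c1ccc(OC)c(OC)c1`: 69%

In a functional assay on the whole organism (strain albino) for inhibition, with Rattus norvegicus as the target, read by paw edema, with stated times of 30 min and 4 h, at a dose of 0.28 mmol/kg by the oral route (on this read-out higher numbers stand for more inhibition at the one dose given (going by the name of the read-out) and lower numbers for less inhibition), compound 1 gives 67% and compound 2 gives 69%. The two differ by methoxy in place of hydrogen on an aromatic carbon, and that change made a number 2 percentage points higher from compound 1 to compound 2 (within the scatter). Compound 3 gives 69%; the difference between its core and the core of compound 1 is not broken down here. The unmeasured compound 4, `CCn1c(SCC(=O)Nc2ccc(C(C)=O)cc2)nnc1-c1cc(OC)c(OC)c(OC)c1`, differs from compound 3 by methoxy in place of hydrogen on an aromatic carbon. This is the same kind of change as that from compound 1 to compound 2, though the place is not the same: here the entering group sits ortho to a methoxy group, meta to a large group and meta to a methoxy group, whereas before it sat para to a large group. Because a number 2 percentage points higher from compound 1 to compound 2 (within the scatter) stayed within the scatter, compound 4 is expected to show a number 1 percentage points higher from compound 3 to compound 4 (within the scatter). Compound 4 is therefore estimated at 70%, between 60% and 80%.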

Compound 4, a percentage reported as inhibition, in the whole organism at one dose (the size of the read-out at that dose, not a potency): 68%
For compound 4 the middle estimate is 2 percentage points above the measured one, and the stated range covers the measured number.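

In this assay, methoxy in place of hydrogen on an aromatic carbon gave a number 1 percentage points lower from compound 3 to compound 4 (within the scatter). Set beside the earlier step, the change reads the same on both cores: the same change on two cores in this assay, a number 2 percentage points higher (within the scatter) from compound 1 to compound 2 and a number 1 percentage points lower (within the scatter) from compound 3 to compound 4, 3 percentage points apart, within the scatter of two such steps This shows that, on these two cores and at the two places concerned, the change had no effect that can be told from the scatter, but it does not show how the change would behave on other cores, at other places or at other doses.

The compounds shown leave open whether an amine or a carboxylic acid on the same aromatic carbon would give a different reading in this assay. They also leave open whether a longer alkoxy chain would do so.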